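Isopropyl to Methyl on the Phenyl Ring of Compound 3

A few compounds are considered here, and "the series" means these few. Any claim that something is new, unique, unknown or untested is made for them only; others in the source may bear on it.

Compound 1 `CC(C)c1ccc(-c2nc(SCc3cn(CC(=O)NC(=O)Nc4ccccn4)nn3)nc(Nc3ccc(F)cc3)c2C#N)cc1` gives 17500 nM in a functional assay on MGC-803 cells (Homo sapiens) for inhibition, read by MTT assay, with a stated time of 72 h; on this read-out higher numbers stand for weaker inhibition and lower numbers for stronger inhibition.
Compound 2 `CC(C)c1ccc(-c2nc(SCc3cn(CC(=O)NC(=O)Nc4ccccn4)nn3)nc(Nc3ccc(Cl)cc3)c2C#N)cc1` is reported in this assay only as a limit of the assay, > 64000 nM.
Compound 3 `CC(C)c1ccc(Nc2nc(SCc3cn(CC(=O)NC(=O)Nc4ccccn4)nn3)nc(-c3ccc(C(C)C)cc3)c2C#N)cc1` gives 15800 nM in this assay.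

Among the numbers shown, compound 3 sits lowest, but compound 1 lies within the scatter of it, so the two cannot be told apart. Of the three values, one is a limit rather than a number (the limit of > 64000 nM in this assay, at which 1 of the 3 values shown sits). The step of a 1.1-fold lower number from compound 1 to compound 3 (0.04 log units; within the scatter) is within the scatter, whereas an at least 3.6-fold higher number from compound 1 to compound 2 (0.56 log units; beyond the scatter) and an at least 4.0-fold lower number from compound 2 to compound 3 (0.60 log units; beyond the scatter) both lie beyond it.

Compound 4 `Cc1ccc(-c2nc(SCc3cn(CC(=O)NC(=O)Nc4ccccn4)nn3)nc(Nc3ccc(C(C)C)cc3)c2C#N)cc1` differs from compound 3 by methyl in place of isopropyl on an aromatic carbon. Among the measured compounds shown here, the steps that bear on this position are a 1.1-fold lower number from compound 1 to compound 3 (0.04 log units; within the scatter), which changed nothing beyond the scatter, and an at least 4.0-fold lower number from compound 2 to compound 3 (0.60 log units; beyond the scatter), which was clearly larger. Exchanging isopropyl for fluoro at this position left the number where it was, so trimming isopropyl to methyl is expected to move it little. For compound 4 the estimate in this assay is therefore 20000 nM, with a range from 8000 nM to 50000 nM. That is expected to amount to a 1.3-fold higher number from compound 3 to compound 4 (0.10 log units; within the scatter), within the scatter.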

Compound 4, half-maximal inhibitory concentration: 19300 nM
For compound 4 the middle estimate is 1.0-fold (0.02 log units) above the measured one; the range from low to high includes it.
By their numbers in this assay, from the lowest: compounds 3, 1 and 4 (each within the scatter of the next). At a limit, above all of these: compound 2.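

Among the compounds shown here, compounds 1, 2 and 3 all carry the 4-isopropylphenyl group that compound 4 alters, so their steps concerned a different aromatic ring, and compound 4 gives the first reading of this position in this assay. Trimming isopropyl to methyl here gives a 1.2-fold higher number from compound 3 to compound 4 (0.09 log units; within the scatter), so at this place, on the ring of carbon only, methyl and isopropyl cannot be told apart on this read-out, and the 4-methylphenyl group keeps compound 4 in the same range as compound 3. Nothing in the data shown accounts for this flat result.

The compounds shown hold only isopropyl and methyl at this place, so it stays open whether a longer chain such as butyl, a hydroxyl or an amine would leave the number in the same range. Also open, as far as these compounds go, is whether methyl would behave the same way with fluoro or chloro on the other aromatic ring, the groups found in compound 1 and compound 2, in place of the isopropyl that compound 4 keeps there.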